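Amide for thiazolylamine on the shared core

The source may report more compounds than this note shows. Statements on the series, on what has been measured and on what is new or still open speak of the compounds shown alone.

Among the measured compounds shown here, compound 1 `CC(C)C(Nc1nccs1)c1ccc(-c2ccc3cccc(F)c3c2)[nH]c1=O` is one of three compounds measured in a physicochemical assay for solubility, measured as kinetic solubility, at pH 2; a higher number here means a more soluble compound, a lower number a less soluble compound. Compound 1 gives 32900 nM. Compound 2 `CCn1ncc2c(F)cc(-c3ccc(C(CC)(CC)c4nnc(C)[nH]4)c(=O)[nH]3)cc21` gives 33900 nM, and compound 3 `CC(C)[C@H](C[C@H]1CCNC1=O)c1ccc(-c2ccc3cccc(F)c3c2)[nH]c1=O` gives 38300 nM; all three numbers lie within the usual scatter of one another, so no ordering among them can be read. Compound 4 `CC(C)C(CC(N)=O)c1ccc(-c2ccc3cccc(F)c3c2)[nH]c1=O` has not yet been measured. It differs from compound 1 in one place: carbamoylmethyl in place of (1,3-thiazol-2-yl)amino on a saturated chain carbon bound to an aromatic carbon and a saturated chain carbon. For the measured compounds named here, no measured pair carries this change, so the expectation rests on the change alone. For compound 4 the step in this assay is expected to be small and, if anything, toward higher solubility, a 1.4-fold higher number from compound 1 to compound 4 (0.14 log units; within the scatter). Compound 4 is estimated at 45000 nM, with a range from 20000 nM to 100000 nM.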

Compound 4, solubility: 3120 nM
Compound 4: the middle estimate sits 14-fold (1.16 log units) above what was measured, and the stated range ends above it.
By their numbers in this assay, from the lowest: compound 4; then compounds 1, 2 and 3 (each within the scatter of the next).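

In this assay the saturated chain carbon bound to an aromatic carbon and a saturated chain carbon proves sensitive to substitution: carbamoylmethyl in place of (1,3-thiazol-2-yl)amino gives an 11-fold lower number from compound 1 to compound 4 (1.02 log units; beyond the scatter) on the shared core. Among the compounds shown here, the earlier compounds offered no pair differing in one place, so this is the first reading of this position. Nothing on hand accounts for the size of this step.

On these data alone, with one pair, it stays open whether the drop follows the loss of (1,3-thiazol-2-yl)amino or the arrival of carbamoylmethyl. Also open, as far as these compounds go, is how a carboxylic acid or an amine on this carbon would read in this assay on the same core.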